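Aryl entry at the amide nitrogen of compound 2

This account rests on a few compounds, and the source may have more. Where it says the series, first, only, none or still open, it means among the compounds named here.

Measured so far:
compound 1, `COC(=O)/C=C/c1ccc2c(c1)C(=O)C(=O)N2Cc1cc(C)cc(C)c1`: 40 nM
compound 2, `CCN1C(=O)C(=O)c2cc(/C=C/C(=O)OC)ccc21`: 170 nM
compound 3, `COC(=O)/C=C/c1ccc2c(c1)C(=O)C(=O)N2`: 220 nM

In a functional assay on K562 cells (Homo sapiens) for cytotoxicity, read by MTT assay, with a stated time of 48 h (a lower number here means a stronger inhibitor, a higher number a weaker inhibitor), compound 2 gives 170 nM, a number higher than that of compound 1 and close to that of compound 3; its step to compound 3, a 1.3-fold higher number from compound 2 to compound 3 (0.11 log units; within the scatter), lies within the scatter, while its step to compound 1 is beyond it. Compound 4, `COC(=O)/C=C/c1ccc2c(c1)C(=O)C(=O)N2Cc1ccc(OC)cc1`, is not yet measured. It differs from compound 2 in one place: 4-methoxyphenyl in place of methyl on a saturated chain carbon bound to an amide-type nitrogen in a ring. Within the data shown here, the only measured step that bears on this change is the one in the reverse sense, a 4.3-fold higher number from compound 1 to compound 2 (0.63 log units; beyond the scatter), where a 3,5-dimethylphenyl leaving the same saturated chain carbon raised the number. Since an aromatic ring again enters on that carbon, a step in the opposite direction, towards a lower number in this assay, is expected, though the substitution on the ring is not the same, so the size is uncertain. Compound 4 is therefore estimated at 60 nM, in the range 25 nM to 150 nM, which means an expected step of a 2.8-fold lower number from compound 2 to compound 4 (0.45 log units; beyond the scatter).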

Compound 4, half-maximal inhibitory concentration: 3 nM
The estimate for compound 4 lay 20-fold (1.30 log units) above the measured number; measured number outside the range, below it.
By their numbers in this assay, from the lowest: compound 4; then compound 1; then compounds 2 and 3 (each within the scatter of the next).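

In this assay, among these compounds, 4-methoxyphenyl in place of methyl on this saturated chain carbon gives a 57-fold lower number from compound 2 to compound 4 (1.75 log units; beyond the scatter) and shows that the position can yield a far larger gain than the earlier compounds indicated. Among the compounds shown here, the earlier compounds held only one aromatic group here, whereas 4-methoxyphenyl in place of 3,5-dimethylphenyl gives a 13-fold lower number from compound 1 to compound 4 (1.12 log units; beyond the scatter) and shows that the substitution on the ring matters, not merely the presence of a ring. Nothing measured here accounts for the difference between these two rings.

Going by these compounds, it remains open whether the methoxy group itself carries the gain, a question that an unsubstituted phenyl on the same carbon would address. On these data alone, how an amine, a carboxylic acid or a longer chain would fare on this carbon also remains open.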